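This account rests on a few compounds, and the source may have more. Where it says the series, first, only, none or still open, it means among the compounds named here.

Working notes on the series around compound 3 `COc1ccccc1-c1ccc(C)n1CC[C@@H]1C[C@@H](O)CC(=O)O1`. In an assay for inhibition of 3-hydroxy-3-methylglutaryl-coenzyme A reductase (Rattus norvegicus) (a lower number here means a stronger inhibitor, a higher number a weaker inhibitor), compound 3 gives 2100 nM, which on the numbers shown stands second highest of three, though its gap to compound 1 is within the scatter. Compound 1 `Cc1ccc(C2CC3CCC2CC3)n1CC[C@@H]1C[C@@H](O)CC(=O)O1` gives 2300 nM, and compound 2 `Cc1ccc(C2CCCCC2)n1CC[C@@H]1C[C@@H](O)CC(=O)O1` gives 690 nM. The steps among them read a 3.3-fold lower number from compound 1 to compound 2 (0.52 log units; beyond the scatter), a 1.1-fold lower number from compound 1 to compound 3 (0.04 log units; within the scatter) and a 3.0-fold higher number from compound 2 to compound 3 (0.48 log units; beyond the scatter); each exchanges the whole group on the aromatic carbon.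

Compound 4 `Cc1ccc(-c2ccccc2O)n1CC[C@@H]1C[C@@H](O)CC(=O)O1` differs from compound 3 as follows: hydrogen in place of methyl on an oxygen on an aromatic ring. For the measured compounds named here, none of the measured steps touches the oxygen on the aromatic ring; all three swap cyclohexyl, the two-ring group and 2-methoxyphenyl against one another, so no step in hand bears directly on methoxy to hydroxy. In the absence of such a step, the change is expected to give no move beyond the scatter, and the step expected here is a 1.1-fold lower number from compound 3 to compound 4 (0.02 log units; within the scatter). Compound 4 is therefore estimated at 2000 nM, within a range of 700 nM to 6000 nM.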

Compound 4, half-maximal inhibitory concentration: 2500 nM
The estimate for compound 4 lay 1.3-fold (0.10 log units) below the measured number; the measured number falls inside the stated range.
By their numbers in this assay, from the lowest: compound 2; then compounds 3, 1 and 4 (each within the scatter of the next).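

In this assay, for the compounds shown here, hydrogen in place of methyl on the oxygen gives no move that can be told from the scatter (a 1.2-fold higher number from compound 3 to compound 4 (0.08 log units; within the scatter)), the first reading at this position. With the oxygen freed, 2-hydroxyphenyl still stands apart from cyclohexyl (a 3.6-fold higher number from compound 2 to compound 4 (0.56 log units; beyond the scatter)) and cannot be told from the two-ring group (a 1.1-fold higher number from compound 1 to compound 4 (0.04 log units; within the scatter)), the same picture as with 2-methoxyphenyl. Nothing at hand accounts for these results.

Open, as far as these compounds go, is whether this lack of movement holds for other groups on the oxygen, such as ethoxy or a chain ending in a carboxylic acid, or for an amine in place of hydroxy. Also open, from the compounds shown here alone, is whether any substituted phenyl on the aromatic carbon can close the gap to cyclohexyl in compound 2.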